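Cyclopentyl to cyclooctyl: one ring change, one open question

A few compounds are considered here, and "the series" means these few. Any claim that something is new, unique, unknown or untested is made for them only; others in the source may bear on it.

Compound 1 `O=C1Nc2c(ccc(F)c2F)C1(c1ccc(O)cc1)c1cccnc1` gives 63 nM
Compound 2 `O=C1Nc2c(ccc(F)c2F)C1(c1ccc(O)cc1)C1CCCC1` gives 12 nM

For the measured compounds named here, in a functional assay on MCF7 cells (Homo sapiens) for cytotoxicity, read by WST assay, with a stated time of 72 h (on this read-out lower numbers stand for stronger inhibition and higher numbers for weaker inhibition), compound 2, at 12 nM here, holds the lower of the two numbers so far, and compound 1 gives 63 nM in the same test. Compound 3 `O=C1Nc2c(ccc(F)c2F)C1(c1ccc(O)cc1)C1CCCCCCC1` shares the core of compound 2 and alters one group, with cyclooctyl in place of cyclopentyl on a saturated ring carbon describes the swap.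

Going by the values given here, only one measured step involves this carbon. It is a 5.3-fold lower number from compound 1 to compound 2 (0.72 log units; beyond the scatter) and comes with cyclopentyl in place of pyridin-3-yl. That modest step shows that the group on this carbon can move the number. However, no measured pair compares two carbon-only rings of different size, so it offers only a rough guide. In this assay a smaller step is therefore expected, tilted slightly towards a higher number and probably not beyond the scatter. The estimate amounts to a 1.7-fold higher number from compound 2 to compound 3 (0.22 log units; within the scatter) as the expected step. For compound 3 the expected value is 20 nM (estimated range 6 nM to 70 nM).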

Compound 3, half-maximal inhibitory concentration: > 1000 nM
Compound 3 was reported as a limit (the forecaster's own chance of this, stated with the estimate: 3%); middle value at least 50-fold (1.69 log units) from the limit.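

In this assay, for the compounds shown here, the size of a carbon-only ring on this saturated ring carbon matters far more than the earlier compounds suggested: cyclooctyl in place of cyclopentyl gives an at least 83-fold higher number from compound 2 to compound 3 (1.92 log units; beyond the scatter). Cyclooctyl also compares poorly with the pyridin-3-yl group, with an at least 15-fold higher number from compound 1 to compound 3 (1.20 log units; beyond the scatter), and this step is larger than the only one seen before on this carbon, which was a 5.3-fold lower number from compound 1 to compound 2 (0.72 log units; beyond the scatter). Compound 3 is reported only as a limit and not as a number, so both new steps give only a minimum size: the limit of > 1000 nM in this assay, at which 1 of the 3 values shown sits.

The compounds shown jump from a five-membered to an eight-membered carbon-only ring, so it remains open where in that range the number starts to rise, and a cyclohexyl or cycloheptyl group on the same carbon would help to narrow this down. Going by these compounds, it also remains open whether ring size itself or simply the larger count of carbon atoms goes with the loss, a question that an open chain such as n-octyl, or a smaller ring carrying an amine, could begin to address.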